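Working notes: replacing the aryl group of compound 3

This account rests on a few compounds, and the source may have more. Where it says the series, first, only, none or still open, it means among the compounds named here.

Values in a functional assay on CCRF-CEM cells (Homo sapiens) for inhibition, read by MTT assay, with a stated time of 72 h; on this read-out lower numbers stand for stronger inhibition and higher numbers for weaker inhibition:
- compound 1 `COc1cc(NC(C)CCCNC(=O)Nc2cccc(O)c2)c2ncccc2c1`: 32000 nM
- compound 2 `COc1cc(NC(C)CCCNC(=O)NNC(=O)Nc2cccc(F)c2)c2ncccc2c1`: 98000 nM
- compound 3 `COc1cc(NC(C)CCCNC(=O)NNC(=O)Nc2cccc(C(F)(F)F)c2)c2ncccc2c1`: 6900 nM

Compound 3 has the lowest number of the three. Compound 4 `COc1cc(NC(C)CCCNC(=O)NNC(=O)Nc2ccc(O)cc2)c2ncccc2c1` carries 4-hydroxyphenyl in place of 3-(trifluoromethyl)phenyl on an amide-type nitrogen. Within the data shown here, two measured steps bear on this change. The large one is a 14-fold lower number from compound 2 to compound 3 (1.15 log units; beyond the scatter), with trifluoromethyl in place of fluoro. Among the measured compounds shown here, the modest one is a 3.1-fold higher number from compound 1 to compound 2 (0.49 log units; beyond the scatter), which links the only measured hydroxyphenyl compound to this series. A clear rise in this assay is therefore expected on losing trifluoromethyl, though probably not a full reversal of the large step. The expected step is a 5.8-fold higher number from compound 3 to compound 4 (0.76 log units; beyond the scatter). For compound 4 the estimate is 40000 nM, with an expected range of 13000 nM to 120000 nM.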

Compound 4, half-maximal inhibitory concentration: 111000 nM
For compound 4 the middle estimate is 2.8-fold (0.44 log units) below the measured one; measured number inside the range.
By their numbers in this assay, from the lowest: compound 3; then compound 1; then compounds 2 and 4 (each within the scatter of the next).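

Replacing 3-(trifluoromethyl)phenyl with 4-hydroxyphenyl gives up the whole advantage of that group in this assay, with a 16-fold higher number from compound 3 to compound 4 (1.21 log units; beyond the scatter). 4-Hydroxyphenyl and 3-fluorophenyl cannot be told apart on this nitrogen, with a 1.1-fold higher number from compound 2 to compound 4 (0.05 log units; within the scatter), so among these three aryl groups only 3-(trifluoromethyl)phenyl stands out. The step of a 3.5-fold higher number from compound 1 to compound 4 (0.54 log units; beyond the scatter) replaces 3-hydroxyphenyl with ((4-hydroxyphenyl)carbamoyl)amino, so it changes both the linker and the place of the hydroxyl and cannot separate the two.

No measured evidence explains these steps. On these data alone, whether 4-(trifluoromethyl)phenyl or 3-chlorophenyl would keep the low number remains open.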